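Tert-Butyl for Fluoro on the Aryl Tail of Compound 3

The compounds below may be only part of what the source reports. "The series", "measured", "known", "first", "only" and "open" are said of these compounds alone.

Compound 1, `COc1ccc(F)cc1CNCCCNc1ccnc2cc(CCC(C)C)ccc12`: 890 nM in an ADME assay on HepG2 cells (Homo sapiens) for cytotoxicity, read by luminescence, CellTiter-Glo and ATP content, with a stated time of 72 h; a higher number here means that more compound is needed for the effect, a lower number that less compound is needed
Compound 2, `COc1ccc(F)cc1CNCCCNc1ccnc2cc(CC(C)C)ccc12`: 2900 nM
Compound 3, `COc1ccc(F)cc1CNCCCNc1ccnc2cc(-c3ccc(F)cc3)ccc12`: 770 nM

In this assay compound 3 stands lowest of the three. Compound 1 lies nearest, and a 1.2-fold lower number from compound 1 to compound 3 (0.06 log units; within the scatter) is within the scatter; compound 2 lies furthest, with a 3.8-fold lower number from compound 2 to compound 3 (0.58 log units; beyond the scatter). Compound 4, `COc1ccc(F)cc1CNCCCNc1ccnc2cc(-c3ccc(C(C)(C)C)cc3)ccc12`, differs from compound 3 by tert-butyl in place of fluoro on an aromatic carbon. Among the measured compounds shown here, no measured step changes a group on that phenyl ring; the steps that bear on it only bring the 4-fluorophenyl in, and a 1.2-fold lower number from compound 1 to compound 3 (0.06 log units; within the scatter) shows that this swap hardly moved the number, while a 3.3-fold higher number from compound 1 to compound 2 (0.51 log units; beyond the scatter) was modest. The step is therefore expected to be small, a 1.2-fold lower number from compound 3 to compound 4 (0.07 log units; within the scatter), in either direction or none beyond the scatter. Compound 4 is estimated at 650 nM, within 250 nM to 1700 nM.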

Compound 4, half-maximal effective concentration: 620 nM
Beside the measured number, compound 4's estimate is 1.0-fold (0.02 log units) above it, and the stated range covers the measured number.
By their numbers in this assay, from the lowest: compounds 4, 3 and 1 (each within the scatter of the next); then compound 2.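

Tert-butyl in place of fluoro is the first change shown on the phenyl ring itself, and in this assay it leaves the number within the scatter (a 1.2-fold lower number from compound 3 to compound 4 (0.09 log units; within the scatter)). Against the alkyl groups, 4-(tert-butyl)phenyl behaves as 4-fluorophenyl did: the number stays within the scatter of the isopentyl compound (a 1.4-fold lower number from compound 1 to compound 4 (0.16 log units; within the scatter)) and lies beyond the scatter of the isobutyl compound (a 4.7-fold lower number from compound 2 to compound 4 (0.67 log units; beyond the scatter)).

Going by these compounds, whether an amine or a carboxylic acid on the same ring carbon would also leave the number in place stays open. Nothing shown bears on why this change leaves the number where it is.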